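A few compounds are considered here, and "the series" means these few. Any claim that something is new, unique, unknown or untested is made for them only; others in the source may bear on it.

Of the compounds shown here, three with a shared core have been tested so far: compound 1 `O=C(O)CCCCCNC(=O)c1cc(=O)c2ccccc2o1`, compound 2 `Cn1nnnc1NC(=O)c1cc(=O)c2ccccc2o1` and compound 3 `O=C(O)CCNC(=O)c1cc(=O)c2ccccc2o1`. The test is a functional assay on cells (Mast cell, Rattus norvegicus) for inhibition, with a stated time of 15 min; a higher number here means that more compound is needed for the effect, a lower number that less compound is needed. Compound 1 gives > 18 ug/mL, which is a limit and not a number. Compound 2 gives > 18 ug/mL, also a limit. Compound 3 gives > 18 ug/mL, again a limit, so it has no exact place on the scale. The picture so far is the limit of > 18 ug/mL in this assay, at which 3 of the 3 values shown sit.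

Compound 4 `O=C(Nc1nccs1)c1cc(=O)c2ccccc2o1` carries 1,3-thiazol-2-yl in place of 2-carboxyethyl on an amide-type nitrogen.

Among the measured compounds shown here, two measured steps bear on this change: a step that the two limits leave unreadable from compound 1 to compound 3, and a step that the two limits leave unreadable from compound 2 to compound 3. The second is the closer, since it also replaces the group on that nitrogen. Neither has a readable size, so no size or direction can be carried over to this assay, and no clear change is expected.

The estimated outcome is a step that the limit leaves unreadable from compound 3 to compound 4. For compound 4 the expected value is 30 ug/mL, within an estimated range of 12 ug/mL to 80 ug/mL.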

Compound 4, concentration for half-maximal effect: > 18 ug/mL
Compound 4 gave a limit, no number; the forecaster's own chance of this, stated with the estimate: 70%; the middle value does not contradict the limit.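

Compound 4 gives a limit and not a number, like compound 2 and compound 3, so the steps linking it to them cannot be read: the limit of > 18 ug/mL in this assay, at which 4 of the 4 values shown sit.

The compounds shown leave open whether any group on the amide-type nitrogen gives a measurable value in this assay.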